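The source may hold more compounds than are shown below. What is called first, only, known or untested is meant among the compounds shown, and "the series" means these compounds.

Measured so far in an ADME assay on CHO-K1 cells (Cricetulus griseus) for cytotoxicity, read by MTT assay, with a stated time of 24 h (a lower number here means a stronger inhibitor, a higher number a weaker inhibitor), are two compounds:
- compound 1 `CCCCCCCC/C=C\CCCCCCCC(=O)Nc1nnc(S[C@@H]2O[C@H](COC(C)=O)[C@H](OC(C)=O)[C@H](OC(C)=O)[C@H]2OC(C)=O)s1` gives 26300 nM as its value
- compound 2 `CCCCCCCCCCCC(=O)Nc1nnc(S[C@@H]2O[C@H](CO)[C@H](O)[C@H](O)[C@H]2O)s1` is reported as "not active" (no number reported) with no number given

Within the data shown here, compound 1 therefore holds the only number in the set, and compound 2 offers no number to set against it. The next compound is compound 3 `CCCCCCCCCC(=O)Nc1nnc(S[C@@H]2O[C@H](COC(C)=O)[C@H](OC(C)=O)[C@H](OC(C)=O)[C@H]2OC(C)=O)s1`, which keeps the core of compound 1 and differs only in its chain. The change is ethyl in place of dec-1-en-1-yl on a saturated chain carbon, seven bonds along the chain from a carbonyl carbon; in words, ethyl in place of dec-1-en-1-yl on a saturated chain carbon, seven bonds along the chain from a carbonyl carbon. Among the measured compounds shown here, no measured step shows what such a change does in this assay, so the data give no direction. The expectation is thus no shift beyond the usual scatter, with wide uncertainty, and a result without a number remains possible. This expectation rests on compound 1 alone, at 26300 nM as the only anchor. The estimated change is a 1.1-fold lower number from compound 1 to compound 3 (0.02 log units; within the scatter) and is expected to be small. For compound 3 the expected value is 25000 nM with an estimated range from 8000 nM to 80000 nM at this stage.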

Compound 3, half-maximal inhibitory concentration: 19400 nM
For compound 3 the middle estimate is 1.3-fold (0.11 log units) above the measured one; low and high end bracket the measured number.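

In this assay the exchange of dec-1-en-1-yl for ethyl, on a saturated chain carbon, seven bonds along the chain from a carbonyl carbon, gives a 1.4-fold lower number from compound 1 to compound 3 (0.13 log units; within the scatter) and so stays inside the usual scatter of repeated measurements. Among these compounds, this is the first step that can be read at this position, and it shows that, with the shared core unchanged, this assay does not tell the two chains apart, even though the double bond leaves together with much of the chain's length. No measurement shown offers an explanation for this result.

Among the compounds shown here, compound 2 differs from compound 1 and compound 3 in more than one place and has no number, so no step involving it can be read. Going by these compounds, it remains open whether a longer saturated chain, an amine or a carboxylic acid at this position would move the number in this assay beyond the scatter, and a single step cannot show how far this lack of separation extends.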